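Cytotoxicity Notes on the Series, Toward Compound 4

This account rests on a few compounds, and the source may have more. Where it says the series, first, only, none or still open, it means among the compounds named here.

Measured so far in an ADME assay on L02 cells (Homo sapiens) for cytotoxicity, read by MTT assay, with a stated time of 48 h; on this read-out higher numbers stand for weaker inhibition and lower numbers for stronger inhibition:
- compound 1 `CCN(CC)c1ccc2cc(C(=O)c3ccc(N4CCN(C(=O)CN5CCN(C(=O)CCl)CC5)CC4)cc3)oc2c1` gives 20900 nM
- compound 2 `CCN(CC)c1ccc2cc(C(=O)c3ccc(N4CCN(C(=O)CN5CCN(S(=O)(=O)C6CC6)CC5)CC4)cc3)oc2c1` gives > 100000 nM, which is a limit of the assay and not a number
- compound 3 `CCN(CC)c1ccc2cc(C(=O)c3ccc(N4CCN(C(=O)CN5CCN(S(=O)(=O)c6ccc(F)cc6)CC5)CC4)cc3)oc2c1` gives 9240 nM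

Compound 1 holds the highest of the two numbers shown in this assay ; its nearest neighbour is compound 3, with a 2.3-fold lower number from compound 1 to compound 3 (0.35 log units; beyond the scatter). The third value, that of compound 2, sits at the limit described by the limit of > 100000 nM in this assay, at which 1 of the 3 values shown sits.

Compound 4 `CCN(CC)c1ccc2cc(C(=O)c3ccc(N4CCN(C(=O)CN5CCN(CC(C)=O)CC5)CC4)cc3)oc2c1` is the next compound to be measured. It differs from compound 1 in one place: 2-oxopropyl in place of (chloromethyl)carbonyl on an amine nitrogen in a ring.

Among the measured compounds shown here, two measured steps touch the same position. Replacing the (chloromethyl)carbonyl with cyclopropylsulfonyl gave an at least 4.7-fold higher number from compound 1 to compound 2 (0.67 log units; beyond the scatter), while replacing it with (4-fluorophenyl)sulfonyl gave a 2.3-fold lower number from compound 1 to compound 3 (0.35 log units; beyond the scatter); between those two, an at least 10-fold lower number from compound 2 to compound 3 (1.03 log units; beyond the scatter). The direction therefore depends on what enters, and 2-oxopropyl is neither of the groups measured. With the number of compound 1 as the anchor and the two steps pulling opposite ways, a higher number, in the direction of compound 2, is expected but with wide uncertainty.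

Compound 4 is estimated at 40000 nM in this assay , within a range of 12000 nM to 100000 nM, which corresponds to an expected step of a 1.9-fold higher number from compound 1 to compound 4 (0.28 log units; within the scatter).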

Compound 4, half-maximal inhibitory concentration: > 100000 nM
Compound 4 gave a limit, no number; the forecaster's own chance of this, stated with the estimate: 30%; middle value at least 2.5-fold (0.39 log units) away from the limit.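

Compound 4 gives a limit in this assay, not a number, and compound 2 also gives a limit there: the limit of > 100000 nM in this assay, at which 2 of the 4 values shown sit. Among the compounds shown here, exchanging (chloromethyl)carbonyl for 2-oxopropyl removes the chlorine and gives an at least 4.7-fold higher number from compound 1 to compound 4 (0.67 log units; beyond the scatter), so at this ring nitrogen the move to a limit is no longer seen only with a sulfonyl group, as it was with cyclopropylsulfonyl in compound 2. For the compounds shown here, measured against (4-fluorophenyl)sulfonyl, the same position shows an at least 10-fold higher number from compound 3 to compound 4 (1.03 log units; beyond the scatter), leaving compound 1 and compound 3 as the only members of this set with numbers rather than limits, while the step between compound 2 and compound 4 cannot be read.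

Open, going by these compounds, is whether the chlorine itself separates compound 1 from compound 4, a question that an acetyl group on this nitrogen would help to settle by keeping the carbonyl of compound 1 without the chlorine. Also open, on these data alone, is whether the number of compound 3 depends on the fluorine, the aromatic ring or the sulfonyl link, which phenylsulfonyl or 4-fluorobenzoyl at the same nitrogen would begin to separate.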